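Swapping Isobutyl for Cyclohexylmethyl in a Small Series

This account rests on a few compounds, and the source may have more. Where it says the series, first, only, none or still open, it means among the compounds named here.

In a functional assay for inhibition, with Rattus norvegicus as the target, at pH 7.35 (on this read-out lower numbers stand for stronger inhibition and higher numbers for weaker inhibition), compound 1 `CCOC(=O)C(=O)C(CC)NC(=O)C(CC(C)C)NC(=O)OCc1ccccc1` gives 300000 nM, compound 2 `CCCCOC(=O)C(=O)C(CC)NC(=O)C(CC(C)C)NC(=O)OCc1ccccc1` gives 28000 nM and compound 3 `CCC(NC(=O)C(CC(C)C)NC(=O)OCc1ccccc1)C(=O)C(=O)NCC(C)C` gives 28000 nM. Compound 3 therefore stands level with compound 2, and together they hold the lowest of the three numbers.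

The unmeasured compound 4 `CCC(NC(=O)C(CC(C)C)NC(=O)OCc1ccccc1)C(=O)C(=O)NCC1CCCCC1` keeps the core of compound 3 and alters one group: cyclohexyl in place of isopropyl on a saturated chain carbon bound to an amide-type nitrogen. Put simply, isobutyl becomes cyclohexylmethyl.

Three measured steps changed the group on the same carbonyl carbon. Butoxy in place of ethoxy gave an 11-fold lower number from compound 1 to compound 2 (1.03 log units; beyond the scatter), and isobutylamino in place of ethoxy gave an 11-fold lower number from compound 1 to compound 3 (1.03 log units; beyond the scatter). Isobutylamino in place of butoxy gave no change at the digits printed from compound 2 to compound 3 (within the scatter). None of these steps introduces a ring, so they offer only a loose guide, and neither large step is expected to repeat in full. The step expected in this assay is small and leans towards a lower number: a 1.9-fold lower number from compound 3 to compound 4 (0.27 log units; within the scatter). Compound 4 is estimated at 15000 nM, with an expected range of 4000 nM to 50000 nM.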

Compound 4, half-maximal inhibitory concentration: 66000 nM
Compound 4: the middle estimate sits 4.4-fold (0.64 log units) below what was measured, and the stated range ends below it.
By their numbers in this assay, from the lowest: compounds 2 and 3 (each within the scatter of the next); then compound 4; then compound 1.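

In this assay, where higher numbers mean weaker inhibition, the position tolerates the ring but does not reward it: cyclohexyl in place of isopropyl gives a 2.4-fold higher number from compound 3 to compound 4 (0.37 log units; beyond the scatter) and so moves the series the wrong way by a modest step. The same holds for the group as a whole, as (cyclohexylmethyl)amino in place of butoxy gives a 2.4-fold higher number from compound 2 to compound 4 (0.37 log units; beyond the scatter) while the same group in place of ethoxy still gives a 4.5-fold lower number from compound 1 to compound 4 (0.66 log units; beyond the scatter) and thus keeps part of the gain that isobutylamino brought. Nothing among the data shown accounts for the direction of this step.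

With one ring at this position, the data cannot separate the effect of the ring from that of the added carbons. A straight hexyl chain or a benzyl group on the same amide-type nitrogen remains an open case, and either could help to tell the two apart.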